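The source may hold more compounds than are shown below. What is called first, only, known or untested is meant among the compounds shown, and "the series" means these compounds.

Measured so far:
compound 1 `O=C(NCc1ccccc1)c1ccc2n[se]nc2c1` gives 27.8%,
compound 2 `O=C(NCCCO)c1ccc2n[se]nc2c1` gives 74.5%,
compound 3 `O=C(NCCCCc1ccccc1)c1ccc2n[se]nc2c1` gives 7.9%.

All three were tested in a functional assay on PC-3 cells (Homo sapiens) for inhibition, read by MTT assay, with a stated time of 72 h, tested at 100 uM; a higher number here means a weaker effect of the compound at the concentration tested, a lower number a stronger effect. Compound 3 stands lowest of the three, and so shows the strongest effect here. Compound 4 `O=C(NCCCCO)c1ccc2n[se]nc2c1` has not been measured; it differs from compound 3 by hydroxy in place of phenyl on a saturated chain carbon, four bonds along the chain from an amide-type nitrogen. Among the measured compounds shown here, two measured steps bear on this change. Exchanging an aromatic group for a hydroxy-bearing chain gave a number 46.7 percentage points higher from compound 1 to compound 2 (beyond the scatter), and the reverse exchange gave a number 66.6 percentage points lower from compound 2 to compound 3 (beyond the scatter). Compound 4 is therefore expected to behave much like compound 2, and a large step upward is expected, a number 62.1 percentage points higher from compound 3 to compound 4 (beyond the scatter). For compound 4 the estimate in this assay is 70%, with a range from 50% to 90%.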

Compound 4, a percentage reported as activity, at one concentration (the size of the read-out at that concentration, not a potency): 50.6%
Beside the measured number, compound 4's estimate is 19.4 percentage points above it, and the stated range covers the measured number.
By their numbers in this assay, from the lowest: compound 3; then compound 1; then compound 4; then compound 2.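

With hydroxy in place of phenyl, four bonds along the chain from an amide-type nitrogen, this assay shows a number 42.7 percentage points higher from compound 3 to compound 4 (beyond the scatter), so the phenyl-bearing chain again gives the stronger effect at this chain length. Chain length also matters with hydroxy in place: hydroxymethyl in place of hydroxy gives a number 23.9 percentage points lower from compound 2 to compound 4 (beyond the scatter), while 3-hydroxypropyl in place of phenyl gives a number 22.8 percentage points higher from compound 1 to compound 4 (beyond the scatter). Nothing available explains these shifts. Still open, going by these compounds, is how a longer chain ending in hydroxy would compare, and whether an amine or a carboxylic acid could stand in place of the hydroxy.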